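From 4-Methoxyphenyl to 3-Nitrophenyl on a Shared Core

The compounds below may be only part of what the source reports. "The series", "measured", "known", "first", "only" and "open" are said of these compounds alone.

Of the compounds shown here, three sharing one core have been measured in a functional assay on K562 cells (Homo sapiens) for cytotoxicity, read by sulforhodamine B assay (a lower number here means a stronger inhibitor of growth, a higher number a weaker inhibitor of growth), so far. Compound 1 (`CC1=CC[C@@H]([C@@](C)(O)CCCC(C)(C)NC=S)CC1`) gives 16700 nM and compound 2 (`CC1=CC[C@@H]([C@@](C)(O)CCCC(C)(C)NC(=S)NN)CC1`) gives 20 nM in this test. Placing aminoamino in place of hydrogen on a thiocarbonyl carbon gives an 840-fold lower number from compound 1 to compound 2 (2.92 log units; beyond the scatter) as the largest change seen. Compound 3 (`COc1ccc(/C=N\NC(=S)NC(C)(C)CCC[C@](C)(O)[C@@H]2CC=C(C)CC2)cc1`) gives 220 nM and holds the middle place, with a higher number than compound 2 and a lower one than compound 1. Adding the group that carries the aromatic ring gives an 11-fold higher number from compound 2 to compound 3 (1.04 log units; beyond the scatter) in the second change seen.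

Compound 4 (`CC1=CC[C@@H]([C@@](C)(O)CCCC(C)(C)NC(=S)N/N=C\c2cccc([N+](=O)[O-])c2)CC1`) has not yet been measured. It differs from compound 3 by 3-nitrophenyl in place of 4-methoxyphenyl on a carbon with a double bond to nitrogen in one swap, 3-nitrophenyl in place of 4-methoxyphenyl on a carbon with a double bond to nitrogen. For the measured compounds named here, neither measured step bears directly on this swap, since both changed other parts of the molecule and no measured pair compares two aromatic groups at this place. The best guide is therefore compound 3 at 220 nM itself, and no step beyond the scatter is expected in this assay here. The estimated change is a 1.1-fold higher number from compound 3 to compound 4 (0.06 log units; within the scatter) and so stays small. For compound 4 the expected value is 250 nM within an estimated range of 80 nM to 800 nM in this test.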

Compound 4, concentration for 50% growth inhibition: 20 nM
The estimate for compound 4 lay 13-fold (1.10 log units) above the measured number; the measured number lies below the stated range.
By their numbers in this assay, from the lowest: compounds 2 and 4 (each within the scatter of the next); then compound 3; then compound 1.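

For the compounds shown here, the aromatic group on the carbon with a double bond to nitrogen matters in this assay: 3-nitrophenyl in place of 4-methoxyphenyl gives an 11-fold lower number from compound 3 to compound 4 (1.04 log units; beyond the scatter), a step beyond the scatter at a place where the earlier compounds offered no comparison of two aromatic groups. The result also shows that a group carrying an aromatic ring at this place does not by itself bring a higher number: compound 2 gives 20 nM and compound 4 gives 20 nM, values within the scatter of each other, whereas the earlier step to compound 3 alone could have suggested otherwise. Nothing available gives a reason for the difference between the two aromatic groups.

The swap replaces the 4-methoxyphenyl group as a whole with the 3-nitrophenyl group, so the compounds shown cannot separate the effect of exchanging methoxy for nitro from the effect of where that group sits on the ring. They also leave open how a plain phenyl ring, or a ring bearing an amine or a carboxylic acid, would behave at this place.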